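The source may hold more compounds than are shown below. What is called first, only, known or untested is meant among the compounds shown, and "the series" means these compounds.

Among the compounds with values here, compound 1 `O=C(NCN1CCC(c2cccc[n+]2[O-])CC1)c1cc(Cl)cc(Cl)c1` gives 45 nM in a functional assay on HEK293 cells for agonist activity at D(4) dopamine receptor (Homo sapiens), read by FLIPR (on this read-out higher numbers stand for an effect only at larger amounts of compound and lower numbers for an effect already at smaller amounts), the lower of the two numbers measured so far. Compound 2 `O=C(CN1CCC(c2cccc[n+]2[O-])CC1)Nc1cccc(OC(F)(F)F)c1` gives 135 nM in this assay, a gap that lies beyond the usual scatter. Compound 3 `O=C(NCN1CCC(c2cccc[n+]2[O-])CC1)c1ccc(F)c(Cl)c1` has not yet been measured; it differs from compound 1 by 3-chloro-4-fluorophenyl in place of 3,5-dichlorophenyl on a carbonyl carbon. Within the data shown here, no measured pair shows what such a change does here, so only a modest shift in either direction, or none beyond the scatter, is expected, namely a 1.6-fold higher number from compound 1 to compound 3 (0.19 log units; within the scatter). Compound 3 is therefore estimated at 70 nM, with a likely range from 25 nM to 200 nM.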

Compound 3, half-maximal effective concentration: 63 nM
Compound 3: middle estimate off by 1.1-fold (0.05 log units), on the high side; low and high end bracket the measured number.
By their numbers in this assay, from the lowest: compounds 1 and 3 (each within the scatter of the next); then compound 2.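

In this assay, placing 3-chloro-4-fluorophenyl where 3,5-dichlorophenyl stood on the carbonyl carbon gives a 1.4-fold higher number from compound 1 to compound 3 (0.15 log units; within the scatter) for this pair. Within the data shown here, this is the first direct comparison at this position, and it shows that the two halogen patterns cannot be told apart here: one chlorine can give way to a fluorine, with the other chlorine placed as in the new group, and the number stays within the usual scatter. Still open is what an unsubstituted phenyl, or a methoxy or nitrile group in place of a halogen, would do on this carbonyl carbon, and no measurement at hand offers an explanation for the result.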